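This account rests on a few compounds, and the source may have more. Where it says the series, first, only, none or still open, it means among the compounds named here.

Compound 3 `CCCCCCCCNC(=S)N1[C@@H](CO)[C@H](O)[C@@H](O)[C@@H]1CO` gives 266000 nM in an assay for inhibition of beta-galactosidase (Bos taurus), read by spectrophotometry (a higher number here means a weaker inhibitor, a lower number a stronger inhibitor), the second highest of the three numbers recorded. Its mirror image, compound 1 `CCCCCCCCNC(=S)N1[C@H](CO)[C@@H](O)[C@H](O)[C@H]1CO`, gives 414000 nM. The step of a 1.6-fold lower number from compound 1 to compound 3 (0.19 log units; within the scatter) is paired with the fact that compounds 1 and 3 differ only in the configuration as drawn. Compound 2 `CCCCCCCCCCCC/N=C1/SC[C@@H]2[C@@H](O)[C@H](O)[C@@H](CO)N12`, carrying a dodecyl chain on a different core, gives 32000 nM, well under the number for compound 3. Compound 4 `CCCCCCCCCCCCNC(=S)N1[C@@H](CO)[C@H](O)[C@@H](O)[C@@H]1CO` differs from compound 3 by butyl in place of hydrogen on a saturated chain carbon, eight bonds along the chain from an amide-type nitrogen. For the measured compounds named here, no measured step covers this lengthening on the shared core of compound 1 and compound 3, so the only guide is the low number of compound 2 with the same long chain. Compound 4 is therefore expected to show a downward step, a 2.7-fold lower number from compound 3 to compound 4 (0.42 log units; beyond the scatter), of uncertain size. The estimate for compound 4 is 100000 nM, between 30000 nM and 300000 nM.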

Compound 4, half-maximal inhibitory concentration: 30000 nM
Estimate against measurement, compound 4: 3.3-fold (0.52 log units) above; the range from low to high includes it.
By their numbers in this assay, from the lowest: compounds 4 and 2 (each within the scatter of the next); then compounds 3 and 1 (each within the scatter of the next).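

On the shared core, the lengthening by butyl in place of hydrogen on a saturated chain carbon, eight bonds along the chain from an amide-type nitrogen, gives a step beyond the scatter in this assay (an 8.9-fold lower number from compound 3 to compound 4 (0.95 log units; beyond the scatter)). For the compounds shown here, the only earlier step on this core, the change of configuration (a 1.6-fold lower number from compound 1 to compound 3 (0.19 log units; within the scatter)), stayed within the scatter. Nothing given here accounts for the size of the new step. Open, on these data alone, is whether the mirror-image core of compound 1 answers the same lengthening, and whether a longer chain, or a chain ending in an amine or a carboxylic acid, moves the number further.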